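The compounds below may be only part of what the source reports. "The series", "measured", "known", "first", "only" and "open" are said of these compounds alone.

In an ADME assay on CRL8155 cells (Homo sapiens) for cytotoxicity, read by resazurin assay, with a stated time of 72 h (on this read-out higher numbers stand for an effect only at larger amounts of compound and lower numbers for an effect already at smaller amounts), compound 1 `O=C(NCCC1CCNCC1)Nc1nc2ccc(C(=O)c3ccccc3)cc2[nH]1` gives > 30000 nM, a limit of the assay. Compound 2 `NCCCC(=O)Nc1nc2ccc(C(=O)c3ccccc3)cc2[nH]1` gives > 30000 nM, again a limit. The evidence so far is the limit of > 30000 nM in this assay, at which 2 of the 2 values shown sit. Compound 3 `NCCCCCCC(=O)Nc1nc2ccc(C(=O)c3ccccc3)cc2[nH]1` differs from compound 2 by 3-aminopropyl in place of amino on a saturated chain carbon, three bonds along the chain from a carbonyl carbon. Only a step that the two limits leave unreadable from compound 1 to compound 2 bears on this change and its size cannot be read, so the expected step of a number no higher from compound 2 to compound 3 (the limit leaves the size open) is none beyond the scatter. Compound 3 is estimated at 30000 nM, with an expected range from 12000 nM to 60000 nM.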

Compound 3, half-maximal effective concentration: > 30000 nM
Compound 3: a limit, no number (the forecaster's own chance of this, stated with the estimate: 75%); the middle value sits exactly at the limit.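

Among these compounds, compound 1, compound 2 and compound 3 each give only a limit, so no step among them can be read: the limit of > 30000 nM in this assay, at which 3 of the 3 values shown sit. The compounds shown leave open whether any of them has a measurable effect in this assay.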